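The source may hold more compounds than are shown below. What is called first, only, known or untested is meant among the compounds shown, and "the series" means these compounds.

Compound 1 `Cc1nnc(SCC(=O)[C@H](CC(=O)O)NC(=O)[C@@H](NC(=O)COc2cccc3ccccc23)C(C)C)s1` gives 190000 nM in a functional assay on Jurkat cells (Homo sapiens) for inhibition; a lower number here means a stronger inhibitor, a higher number a weaker inhibitor.
Compound 2 `CC(C)[C@H](NC(=O)COc1cccc2ccccc12)C(=O)N[C@@H](CC(=O)O)C(=O)CSc1nnnn1-c1ccccc1` gives 153000 nM in this assay.

Compound 2 holds the lower of the two numbers, but the step of a 1.2-fold lower number from compound 1 to compound 2 (0.09 log units; within the scatter) lies within the scatter, so the two compounds cannot be told apart. Compound 3 `CC(C)[C@H](NC(=O)COc1cccc2ccccc12)C(=O)N[C@@H](CC(=O)O)C(=O)CSc1nnnn1C` differs from compound 2 by methyl in place of phenyl on an aromatic nitrogen. Among the compounds with values here, only one measured step bears on this, and it swapped the whole ring on the sulfur without moving the number beyond the scatter. A smaller change at the same ring is therefore expected to change little; the expected step is a 1.1-fold higher number from compound 2 to compound 3 (0.05 log units; within the scatter). Compound 3 is estimated at 170000 nM, in a range from 75000 nM to 400000 nM.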

Compound 3, half-maximal inhibitory concentration: > 200000 nM
Compound 3 gave a limit, no number; the forecaster's own chance of this, stated with the estimate: 25%; at least 1.1-fold (0.07 log units) between middle value and limit.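

Compound 3 gave no number in this assay, only a limit: the limit of > 200000 nM in this assay, at which 1 of the 3 values shown sits. From the compounds shown here alone, the steps of an at least 1.3-fold higher number from compound 2 to compound 3 (0.11 log units; that floor lies within the scatter) and an at least 1.0-fold higher number from compound 1 to compound 3 (0.02 log units; that floor lies within the scatter) are floors only, so their true size stays unknown, but methyl in place of phenyl on the aromatic nitrogen shows no sign of a stronger inhibitor. Within the data shown here, this is the first change within the tetrazole itself rather than a swap of the whole ring on the sulfur.

Going by these compounds, whether benzyl or a longer chain on that nitrogen would give a stronger inhibitor stays open, as does the effect of an amine on the ring.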